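Working notes: from compound 2 to compound 3

A few compounds are considered here, and "the series" means these few. Any claim that something is new, unique, unknown or untested is made for them only; others in the source may bear on it.

Measured in a functional assay on A549 cells (Homo sapiens) for cytotoxicity, read by MTT assay, with a stated time of 48 h (on this read-out lower numbers stand for stronger inhibition and higher numbers for weaker inhibition), so far:
- compound 1 `C=C1OC(=O)C=C1Cc1ccc(NC(=O)/C=C/c2ccccc2)cc1` gives 14800 nM
- compound 2 `O=C(/C=C/c1ccc(F)cc1)Nc1ccc(CC2=CC(=O)OC2)cc1` gives 41800 nM

Compound 2 holds the higher of the two numbers, and compound 1 lies lower by more than the usual scatter. Compound 3 `C=C1OC(=O)C=C1Cc1ccc(NC(=O)/C=C/c2ccc(F)cc2)cc1` differs from compound 2 by a group of 7 heavy atoms (5 carbon, 2 oxygen; one five-membered non-aromatic ring with 1 hetero atom) in place of a group of 6 heavy atoms (4 carbon, 2 oxygen; one five-membered non-aromatic ring with 1 hetero atom), on a saturated chain carbon bound to an aromatic carbon and nothing else. For the measured compounds named here, no measured pair isolates this change. Compound 1 carries the same entering group and gives 14800 nM in this assay and so a lower number than compound 2, beyond the scatter, is expected. The expected size of the drop is a 3.0-fold lower number from compound 2 to compound 3 (0.48 log units; beyond the scatter) as an estimate. Compound 3 is estimated at 14000 nM (expected range 6000 nM to 32000 nM).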

Compound 3, half-maximal inhibitory concentration: 3460 nM
For compound 3 the middle estimate is 4.0-fold (0.61 log units) above the measured one, outside the stated range (below it).
By their numbers in this assay, from the lowest: compound 3; then compound 1; then compound 2.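

In this assay, for the compounds shown here, the group with 7 heavy atoms in place of the group with 6 heavy atoms, on a saturated chain carbon bound to an aromatic carbon, gives a 12-fold lower number from compound 2 to compound 3 (1.08 log units; beyond the scatter) as the first matched reading of this change. With the entering group held constant, fluoro in place of hydrogen on an aromatic carbon gives a 4.3-fold lower number from compound 1 to compound 3 (0.63 log units; beyond the scatter), a smaller step than the ring change. Nothing available explains either step. Open, going by these compounds, is whether chloro or methoxy in place of fluoro preserves the lower number, and whether the ring change holds without fluoro.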